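A few compounds are considered here, and "the series" means these few. Any claim that something is new, unique, unknown or untested is made for them only; others in the source may bear on it.

Of the compounds shown here, three built on one shared core have been tested in an assay on isolated protein for displacement of a labelled ligand from Alpha-1A adrenergic receptor (Bos taurus); on this read-out lower numbers stand for stronger inhibition and higher numbers for weaker inhibition. Compound 1 `CN(C)C(=O)c1cccnc1NCCCN1CCN(c2ccccc2)CC1` has only hydrogen on the aromatic carbon in question, and compound 1 gives 2 nM. Compound 2 `CN(C)C(=O)c1cccnc1NCCCN1CCN(c2ccccc2OCC2CC2)CC1` carries a cyclopropylmethoxy group there, and compound 2 gives 0.0794 nM. Compound 3 `CN(C)C(=O)c1cccnc1NCCCN1CCN(c2ccccc2OCC(C)(C)C)CC1` carries a neopentyloxy group, and compound 3 gives 0.794 nM, the second lowest of the three numbers: the step of a 10-fold higher number from compound 2 to compound 3 (1.00 log units; beyond the scatter) is modest, and the step of a 2.5-fold lower number from compound 1 to compound 3 (0.40 log units; beyond the scatter) is also modest.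

Compound 4 `Cc1ccccc1N1CCN(CCCNc2ncccc2C(=O)N(C)C)CC1` is not yet measured. It differs from compound 3 by methyl in place of neopentyloxy on an aromatic carbon. The step that bears most on this is a 2.5-fold lower number from compound 1 to compound 3 (0.40 log units; beyond the scatter), since removing the neopentyloxy group would undo that modest gain, while a 25-fold lower number from compound 1 to compound 2 (1.40 log units; beyond the scatter) shows that a group at this place can matter a great deal. A methyl is closer to hydrogen than to either larger group, so compound 4 is expected to sit near compound 1, with a 1.9-fold higher number from compound 3 to compound 4 (0.28 log units; within the scatter). The estimate for compound 4 in this assay is 1.5 nM, within a range from 0.4 nM to 6 nM.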

Compound 4, inhibition constant: 0.794 nM
Estimate against measurement, compound 4: 1.9-fold (0.28 log units) above; the range from low to high includes it.
By their numbers in this assay, from the lowest: compound 2; then compounds 3 and 4 (each within the scatter of the next); then compound 1.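

In this assay, a methyl on this aromatic carbon does the same job as the much larger neopentyloxy, with no change at the digits printed from compound 3 to compound 4 (within the scatter), even though the group shrinks from 6 heavy atoms to 1 and loses its oxygen. The gain over plain hydrogen therefore survives with a single carbon and no oxygen at this place, as a 2.5-fold lower number from compound 1 to compound 4 (0.40 log units; beyond the scatter) shows, so among these compounds that gain does not depend on the neopentyloxy group. Cyclopropylmethoxy stands apart, with a 10-fold higher number from compound 2 to compound 4 (1.00 log units; beyond the scatter), and since compound 3 also carries an oxygen here, the oxygen alone does not account for the low number of compound 2.

Nothing measured here explains why these groups rank as they do. As far as these compounds go, it also remains open whether an ethyl, a methoxy or a chlorine at this same carbon would sit with compound 4 or come closer to compound 2.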